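The source may hold more compounds than are shown below. What is called first, only, known or untested is meant among the compounds shown, and "the series" means these compounds.

In an assay on CHO cells for displacement of a labelled ligand from Free fatty acid receptor 1 (Homo sapiens), read by scintillation counting, with a stated time of 90 min, in the presence of a further agent that is not named here (a lower number here means a stronger inhibitor, a higher number a weaker inhibitor), compound 2 `COc1ccc(COc2ccc(CCC(=O)O)cc2)cc1-c1c(C)cccc1C` gives 47 nM, the second highest of the three numbers recorded. Its nearest neighbour is compound 3 `Cc1cc(OCC2(O)CCS(=O)(=O)CC2)cc(C)c1-c1cccc(COc2ccc(CCC(=O)O)c(F)c2)c1`, which gives 19 nM, a gap beyond the scatter; the furthest is compound 1 `COc1ccc(-c2c(C)cccc2C)cc1COc1ccc(CCC(=O)O)cc1`, which gives 520 nM, again beyond the scatter. Compound 4 `Cc1cccc(C)c1-c1cccc(COc2ccc(CCC(=O)O)cc2)c1` differs from compound 2 in one place: hydrogen in place of methoxy on an aromatic carbon. Among the measured compounds shown here, no pair of measured compounds isolates this change, so its size cannot be read from the data. A modest rise in the number, just beyond the scatter, is expected, as the step of a 2.3-fold higher number from compound 2 to compound 4 (0.37 log units; beyond the scatter) shows. Compound 4 is estimated at 110 nM, with a range from 40 nM to 300 nM.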

Compound 4, inhibition constant in the Free fatty acid receptor 1 assay: 46 nM
Compound 4: middle estimate off by 2.4-fold (0.38 log units), on the high side; the range from low to high includes it.
By their numbers in the Free fatty acid receptor 1 assay, from the lowest: compound 3; then compounds 4 and 2 (each within the scatter of the next); then compound 1.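

In the Free fatty acid receptor 1 assay, the methoxy ortho to a 2,6-dimethylphenyl group can be exchanged for hydrogen with no measurable difference: a 1.0-fold lower number from compound 2 to compound 4 (0.01 log units; within the scatter). Compound 1 carries its methoxy at another place on the same ring, and there the exchange matters: an 11-fold lower number from compound 1 to compound 4 (1.05 log units; beyond the scatter). In a physicochemical assay for lipophilicity, read by HPLC (a lower number here means a more polar compound, a higher number a more lipophilic compound), compound 2 gives 3.38 and compound 4 gives 4.04. At no cost in the Free fatty acid receptor 1 assay, the methoxy of compound 2 gives the lower number in the physicochemical assay: the measured distribution coefficient of compound 2, 3.38, and of compound 4, 4.04, a number 0.66 log units higher (beyond the scatter)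

The compounds shown leave open whether a hydroxyl or a fluorine at this place would match methoxy in both read-outs. They also leave open how an ethoxy would fare.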